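The source may report more compounds than this note shows. Statements on the series, on what has been measured and on what is new or still open speak of the compounds shown alone.

Compound 3, `O=C(/C(=C\c1ccc(O)c([N+](=O)[O-])c1)SCc1ccc(Br)cc1)c1ccc(Br)cc1`, sits at the weak end of the three numbers gathered so far. Among the measured compounds shown here, in a functional assay on DU-145 cells (Homo sapiens) for inhibition, read by trypan blue exclusion, with a stated time of 96 h (on this read-out lower numbers stand for stronger inhibition of growth and higher numbers for weaker inhibition of growth), compound 3 gives 10000 nM, level with compound 2, `O=C(/C(=C\c1ccc(O)c([N+](=O)[O-])c1)SCc1ccc(Br)cc1)c1ccc(C(F)(F)F)cc1`, which gives 10000 nM; the single one-place step, no change at the digits printed from compound 2 to compound 3 (within the scatter), shows that swapping trifluoromethyl for bromo at this aromatic carbon left the number unchanged. For the measured compounds named here, compound 1, `O=C(/C(=C\c1ccc([N+](=O)[O-])c(O)c1)SCc1ccc(Br)cc1)c1ccc([N+](=O)[O-])cc1`, gives 1000 nM, a lower number, but it differs from compound 3 in more than one place, so no single step connects them.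

Compound 4, `O=C(/C(=C\c1ccc(O)c([N+](=O)[O-])c1)SCc1ccc(Br)cc1)c1ccc([N+](=O)[O-])cc1`, is compound 3 with nitro in place of bromo on an aromatic carbon, on an aromatic carbon para to a large group. Going by the values given here, no measured step tests this exact exchange. Among the compounds with values here, the only step at this carbon shows no effect, while compound 1 shows that a nitro-bearing ketone ring can go with a lower number. Weighing both, a modest gain is expected, with a 2.5-fold lower number from compound 3 to compound 4 (0.40 log units; beyond the scatter) as the anticipated step. Compound 4 is therefore estimated at 4000 nM, within 1000 nM to 12000 nM.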

Compound 4, concentration for 50% growth inhibition: 10000 nM
For compound 4 the middle estimate is 2.5-fold (0.40 log units) below the measured one; low and high end bracket the measured number.
By their numbers in this assay, from the lowest: compound 1; then compounds 2, 3 and 4 (each within the scatter of the next).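

Nitro on this aromatic carbon gives no change at the digits printed from compound 3 to compound 4 (within the scatter) and no change at the digits printed from compound 2 to compound 4 (within the scatter) in this assay and so, among bromo, trifluoromethyl and nitro at this position, the change of group does not separate these compounds. The nitro group on this ring does not by itself go with the lower number, since exchanging 3-hydroxy-4-nitrophenyl for 4-hydroxy-3-nitrophenyl gives a 10-fold higher number from compound 1 to compound 4 (1.00 log units; beyond the scatter) while the 4-nitrophenyl ring stays in place. No measured evidence accounts for either result.

Going by these compounds, whether bromo or trifluoromethyl on this ring would keep the lower number alongside the 3-hydroxy-4-nitrophenyl group remains open. So does whether an amine or a carboxylic acid on this aromatic carbon would shift the number at all.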